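Working notes: from compound 3 to compound 4

The compounds below may be only part of what the source reports. "The series", "measured", "known", "first", "only" and "open" are said of these compounds alone.

Measured in a functional assay on HEL cells (Homo sapiens) for inhibition, read by MTT assay, with a stated time of 48 h; a higher number here means a weaker inhibitor, a lower number a stronger inhibitor:
- compound 1 `O=C(CCCCOc1no[n+]([O-])c1S(=O)(=O)c1ccccc1)NO`: 1030 nM
- compound 2 `O=C(CCCCCCOc1no[n+]([O-])c1S(=O)(=O)c1ccccc1)NO`: 9330 nM
- compound 3 `O=C(COCCOc1no[n+]([O-])c1S(=O)(=O)c1ccccc1)NO`: 6790 nM

Compound 1 alone stands apart at the strong end of this small set. The position of compound 3 follows from two steps: a 6.6-fold higher number from compound 1 to compound 3 (0.82 log units; beyond the scatter), which lies beyond the scatter, and a 1.4-fold lower number from compound 2 to compound 3 (0.14 log units; within the scatter), which lies within it.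

The next compound is compound 4 `O=C(NO)OCCOCCOc1no[n+]([O-])c1S(=O)(=O)c1ccccc1`. The change is ((hydroxycarbamoyl)oxy)methyl in place of hydroxycarbamoyl on a saturated chain carbon bound to an oxygen on a saturated carbon.

Within the data shown here, no measured step covers this exact change, so the guidance is indirect. Chain changes away from compound 1 gave modest steps, such as a 9.1-fold higher number from compound 1 to compound 2 (0.96 log units; beyond the scatter), but the gap of a 1.4-fold lower number from compound 2 to compound 3 (0.14 log units; within the scatter) shows no separation between the two compounds furthest from it. On that basis, no step beyond the scatter is expected in this assay, with only a slight lean towards a higher number.

The expected step is a 1.2-fold higher number from compound 3 to compound 4 (0.07 log units; within the scatter).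

The estimate for compound 4 is 8000 nM, with an expected range of 2500 nM to 25000 nM.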

Compound 4, half-maximal inhibitory concentration: 3730 nM
For compound 4 the middle estimate is 2.1-fold (0.33 log units) above the measured one; the measured number falls inside the stated range.
By their numbers in this assay, from the lowest: compound 1; then compounds 4, 3 and 2 (each within the scatter of the next, the first and the last beyond it).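

In this assay the exchange of hydroxycarbamoyl for ((hydroxycarbamoyl)oxy)methyl on a saturated chain carbon bound to an oxygen on a saturated carbon does not separate the two compounds (a 1.8-fold lower number from compound 3 to compound 4 (0.26 log units; within the scatter)), so this position tolerates a hydroxycarbamoyl group attached through oxygen on a longer chain end. Compound 4 does separate from compound 2 (a 2.5-fold lower number from compound 2 to compound 4 (0.40 log units; beyond the scatter)), which compound 3 did not, yet it stays apart from compound 1 (a 3.6-fold higher number from compound 1 to compound 4 (0.56 log units; beyond the scatter)), and compound 1 remains the strongest of the four. Nothing available here bears on the reason for these steps.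

The compounds shown leave open how a carboxylic acid in place of hydroxycarbamoyl would read in this series, and whether a shorter chain on the core of compound 1 would keep its position. They also leave open whether ((hydroxycarbamoyl)oxy)methyl would behave the same way on the chain of compound 1.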